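This account rests on a few compounds, and the source may have more. Where it says the series, first, only, none or still open, it means among the compounds named here.

In an ADME assay on MT4 cells (Homo sapiens) for cytotoxicity, read by MTT assay, with a stated time of 5 days (a lower number here means that less compound is tolerated, a higher number that more compound is tolerated), the three measured compounds read as follows:
compound 1 `Cc1cc(C#N)cc(C)c1Oc1nc(NC2CCC(NS(=O)(=O)c3cccc(C(F)(F)F)c3)CC2)nc2ccsc12`: 6680 nM
compound 2 `Cc1cc(C#N)cc(C)c1Oc1nc(NC2CCC(NC(=O)c3ccc(F)cc3)CC2)nc2ccsc12`: 3180 nM
compound 3 `Cc1cc(C#N)cc(C)c1Oc1nc(NC2CCC(NS(=O)(=O)c3ccc(F)cc3)CC2)nc2ccsc12`: 3530 nM

Compound 3 holds the second highest of these three numbers, nearest compound 2 and furthest from compound 1, with both gaps inside the scatter. Compound 4 `Cc1cc(C#N)cc(C)c1Oc1nc(NC2CCC(NC(=O)c3ccc(C#N)cc3)CC2)nc2ccsc12` differs from compound 3 by (4-cyanophenyl)carbonyl in place of (4-fluorophenyl)sulfonyl on an amine nitrogen. Among the measured compounds shown here, two measured steps bear on it: the exchange of the carbonyl for the sulfonyl, a 1.1-fold higher number from compound 2 to compound 3 (0.05 log units; within the scatter), and the exchange of the aryl substituent, a 1.9-fold lower number from compound 1 to compound 3 (0.28 log units; within the scatter); neither reached beyond the scatter. Compound 4 is therefore expected to show no step beyond the scatter, a 1.1-fold lower number from compound 3 to compound 4 (0.03 log units; within the scatter). The estimate for compound 4 in this assay is 3300 nM, ranging from 1500 nM to 7500 nM.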

Compound 4, half-maximal cytotoxic concentration: 2620 nM
Compound 4: middle estimate off by 1.3-fold (0.10 log units), on the high side, and the stated range covers the measured number.
By their numbers in this assay, from the lowest: compounds 4, 2, 3 and 1 (each within the scatter of the next, the first and the last beyond it).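

In this assay the exchange of fluoro for cyano on an aromatic carbon, now seen within the carbonyl compounds, stays inside the scatter (a 1.2-fold lower number from compound 2 to compound 4 (0.08 log units; within the scatter)). Exchanging the whole (4-fluorophenyl)sulfonyl for (4-cyanophenyl)carbonyl on the amine nitrogen, with two parts changed at once, also stays inside it (a 1.3-fold lower number from compound 3 to compound 4 (0.13 log units; within the scatter)). Nothing available here gives a cause for these numbers. Still open, going by these compounds, is whether an amine or a carboxylic acid on that aromatic ring, or a longer chain on the amine nitrogen, would give a step beyond the scatter.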